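A few compounds are considered here, and "the series" means these few. Any claim that something is new, unique, unknown or untested is made for them only; others in the source may bear on it.

Among the compounds with values here, compound 2 `COc1ccc(C(=O)Nc2ccc(N3CCN(c4cc(Cl)ccc4C)CC3)cc2C(=O)O)c(OC)c1` is the one member of the series that returns a numeric reading: in a toxicity assay on L3.6pl cells (Homo sapiens) for inhibition, read by ATP content, with a stated time of 72 h (on this read-out lower numbers stand for stronger inhibition and higher numbers for weaker inhibition), compound 2 gives 61600 nM. Compound 1 `COc1ccccc1C(=O)Nc1ccc(N2CCN(Cc3ccccn3)CC2)cc1C(=O)O` reaches only a limit, and in this assay compound 1 gives > 100000 nM, a bound rather than a number. Compound 3 `COc1ccccc1C(=O)Nc1ccc(CN2CCN(c3ccccn3)CC2)cc1C(=O)O` likewise stops at a limit; in this assay compound 3 gives > 10000 nM. Within the data shown here, with two of the three results set by limits (the limit of > 10000 nM in this assay, at which 1 of the 3 values shown sits, (the limit of > 100000 nM in this assay, at which 1 of the 3 values shown sits)), compound 2 stands as the single point from which a step can be taken, and no pair of measured compounds differs in only one place.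

Compound 4 `COc1ccc(C(=O)Nc2ccc(N3CCN(c4cc(Cl)ccc4C)CC3)cc2C(=O)O)cc1` keeps the whole of compound 2 apart from one change: hydrogen in place of methoxy on an aromatic carbon. The rest of the structure is unchanged. Removing a group of this size is expected to shift the reading little, if at all, beyond the scatter, with any movement more likely toward weaker inhibition. Compound 4 is accordingly estimated at 75000 nM, within 25000 nM to 200000 nM, the expected step being a 1.2-fold higher number from compound 2 to compound 4 (0.09 log units; within the scatter).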

Compound 4, half-maximal inhibitory concentration: 16800 nM
Beside the measured number, compound 4's estimate is 4.5-fold (0.65 log units) above it, outside the stated range (below it).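

Hydrogen in place of methoxy on the aromatic carbon ortho to a large group gives, in this assay, a 3.7-fold lower number from compound 2 to compound 4 (0.56 log units; beyond the scatter), the first step in the series that can be read. The reading therefore responds to this position, and the change from 2,4-dimethoxyphenyl to 4-methoxyphenyl moves it toward stronger inhibition, so the methoxy group at this carbon is not needed for the inhibition seen with compound 2. Nothing at hand bears on why the number falls.

Going by these compounds, this is a single pair, so whether the trend holds on other parts of the shared core remains unknown. On these data alone, whether a fluorine atom or a hydroxyl group on this carbon would read like hydrogen or like methoxy stays open, as does the effect on the reading of changing the remaining methoxy group of compound 4.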